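This account rests on a few compounds, and the source may have more. Where it says the series, first, only, none or still open, it means among the compounds named here.

Working notes on the series, step from compound 2 to compound 4.

For the measured compounds named here, compound 2 `O=C(Nc1cc(-c2ccccc2)nn1-c1ccccc1)c1cccc(Cl)c1` gives 200 nM in an assay on isolated protein with metabotropic glutamate receptor 5 (Rattus norvegicus) as the target (a lower number here means that less compound is needed, a higher number that more compound is needed for the effect), the second highest of the three numbers so far. Compound 1 `O=C(Nc1cc(-c2ccccc2)nn1-c1ccccc1)c1ccc(F)c(F)c1` gives 20 nM in this assay, and the step of a 10-fold higher number from compound 1 to compound 2 (1.00 log units; beyond the scatter) is modest but beyond the scatter. Compound 3 `O=C(Nc1cc(-c2ccccc2)nn1-c1ccccc1)c1ccccn1` gives 585 nM, with the step of a 2.9-fold higher number from compound 2 to compound 3 (0.47 log units; beyond the scatter) also beyond the scatter; the step of a 29-fold higher number from compound 1 to compound 3 (1.47 log units; beyond the scatter) is the largest seen here. All three differ only in the aryl group on the carbonyl carbon, so the series reads as a variation at that one place.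

Compound 4 `O=C(Nc1cc(-c2ccccc2)nn1-c1ccccc1)c1ccccc1F` carries the change (2-fluorophenyl in place of 3-chlorophenyl on a carbonyl carbon). Going by the values given here, no measured step puts a 2-fluorophenyl on the carbonyl carbon, and the only compound with fluorine there is compound 1, which differs at two places from compound 4. The steps from compound 1 to compound 2 and from compound 2 to compound 3 show that swapping one aryl for another at this carbonyl moves this assay by modest amounts, in either direction. The expected step of a 2.2-fold lower number from compound 2 to compound 4 (0.35 log units; beyond the scatter) is therefore modest, likely toward a lower number given the fluorine-bearing compound 1 at 20 nM. Compound 4 is estimated at 90 nM, with a range from 20 nM to 400 nM.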

Compound 4, half-maximal effective concentration: 100 nM
The estimate for compound 4 lay 1.1-fold (0.05 log units) below the measured number; measured number inside the range.
By their numbers in this assay, from the lowest: compound 1; then compounds 4 and 2 (each within the scatter of the next); then compound 3.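

In this assay the step of a 2.0-fold lower number from compound 2 to compound 4 (0.30 log units; within the scatter) stays within the scatter, so the 2-fluorophenyl and 3-chlorophenyl groups on the carbonyl carbon are not told apart here. The 2-fluorophenyl group also gives a 5.0-fold higher number from compound 1 to compound 4 (0.70 log units; beyond the scatter) and a 5.9-fold lower number from compound 3 to compound 4 (0.77 log units; beyond the scatter) with both steps beyond the scatter, which shows that a single fluorine on this aryl ring does not match the 3,4-difluorophenyl result, yet the aryl compound still stands apart from the pyridin-2-yl one. No measurement on hand offers a reason for these steps.

The compounds shown leave open whether a second fluorine alone accounts for the gap between 2-fluorophenyl and 3,4-difluorophenyl. Also open, going by these compounds, is how an amine, a carboxylic acid or a longer chain on this aryl ring would read in this assay.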